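From Hydroxyphenyl to Thiophenyl: an Expected Cytotoxicity Shift

The source may hold more compounds than are shown below. What is called first, only, known or untested is meant among the compounds shown, and "the series" means these compounds.

Compound 1 `COC1=C(C)C(=O)/C(=C(O)/C=C/c2ccc(O)cc2)C(=O)C1(C)C` heads a small set of analogues that share one core and differ only in the aromatic group on a double-bonded chain carbon bound to a double-bonded chain carbon. In a functional assay on 1A9 cells (Homo sapiens) for cytotoxicity (on this read-out higher numbers stand for an effect only at larger amounts of compound and lower numbers for an effect already at smaller amounts), compound 1 gives 2.9 ug/mL, the lowest of the two numbers recorded; its nearest neighbour is compound 3 `COC1=C(C)C(=O)/C(=C(O)/C=C/c2ccco2)C(=O)C1(C)C`, which gives 7.9 ug/mL. Going by the values given here, the one step available for comparison is a 2.7-fold higher number from compound 1 to compound 3 (0.44 log units; beyond the scatter). Compound 2 `COC1=C(C)C(=O)/C(=C(O)/C=C/c2ccc(F)cc2)C(=O)C1(C)C` has no result in this assay: its entry reads "not determined" (no result reported).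

Compound 4 `COC1=C(C)C(=O)/C(=C(O)/C=C/c2cccs2)C(=O)C1(C)C` is the next member. thiophen-2-yl in place of 4-hydroxyphenyl on a double-bonded chain carbon bound to a double-bonded chain carbon The step from compound 1 to compound 3 bears on it most directly, since there too a five-membered aromatic ring with one hetero atom replaced the 4-hydroxyphenyl group and the hydrogen-bond donor went with it. Because that earlier step was a 2.7-fold higher number from compound 1 to compound 3 (0.44 log units; beyond the scatter), a modest rise in the number is expected for compound 4 as well, in the same direction, although a single comparison leaves the exact size uncertain. The estimate for compound 4 in this assay is therefore 6 ug/mL, with a range from 2.5 ug/mL to 14 ug/mL, which corresponds to an expected step of a 2.1-fold higher number from compound 1 to compound 4 (0.32 log units; beyond the scatter).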

Compound 4, concentration for half-maximal effect: 4 ug/mL
Compound 4: the middle estimate sits 1.5-fold (0.18 log units) above what was measured, within the range that was stated.
By their numbers in this assay, from the lowest: compounds 1, 4 and 3 (each within the scatter of the next, the first and the last beyond it).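

In this assay, thiophen-2-yl in place of 4-hydroxyphenyl on a double-bonded chain carbon bound to a double-bonded chain carbon gives a 1.4-fold higher number from compound 1 to compound 4 (0.14 log units; within the scatter), so at this position, giving up the hydrogen-bond donor of the 4-hydroxyphenyl group does not by itself produce a step beyond the scatter, as the earlier comparison alone might have suggested. Thiophen-2-yl in place of furan-2-yl gives a 2.0-fold lower number from compound 3 to compound 4 (0.30 log units; within the scatter), which means that the two five-membered aromatic rings, one with sulfur and one with oxygen as the hetero atom, are not separated on this read-out, and that compound 4 lies within the scatter of both compound 1 and compound 3, even though those two lie beyond the scatter of each other. Nothing given here accounts for these numbers, and the set offers no measurement that could explain them.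

Steps to compound 2 cannot be read, since its entry holds no number, so the 4-fluorophenyl group adds nothing to the comparison. On these data alone, whether an amine or a carboxylic acid on the aromatic group at this place, or a longer chain carrying it, would move the number beyond the scatter remains open.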